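Chloro Replaces Hydrogen: From Compound 3 to Compound 4

This account rests on a few compounds, and the source may have more. Where it says the series, first, only, none or still open, it means among the compounds named here.

Three measured compounds share one core and were tested in a functional assay on HL-60 cells (Homo sapiens) for activation, read by flow cytometry, with a stated time of 4 days; a lower number here means that less compound is needed, a higher number that more compound is needed for the effect. Compound 1 `COc1ccc(-n2cnc3cnc(-c4cccc(NC(C)=O)c4)cc32)cc1OC` gives > 30000 nM, which is a limit of the assay rather than a number. Compound 2 `Cc1cc(F)ccc1-c1cc2c(cn1)ncn2-c1ccc2c(c1)CCO2` gives 3 nM. Compound 3 `Fc1ccc(-c2cc3c(cn2)ncn3-c2ccc(OC(F)F)cc2)cc1` gives 10000 nM, the highest of the two numbers, and its gap to compound 2 lies beyond the scatter. Compound 4 `Fc1ccc(-c2cc3c(cn2)ncn3-c2ccc(OC(F)F)cc2)c(Cl)c1` has not been measured; it differs from compound 3 in a single place: chloro in place of hydrogen on an aromatic carbon. Within the data shown here, no measured pair isolates this change, so the expectation rests on compound 3 alone, and a moderate step toward a lower number is expected: a 5.0-fold lower number from compound 3 to compound 4 (0.70 log units; beyond the scatter). Compound 4 is estimated at 2000 nM, with a range from 200 nM to 15000 nM.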

Compound 4, half-maximal effective concentration: 90 nM
For compound 4 the middle estimate is 22-fold (1.35 log units) above the measured one; the measured number lies below the stated range.
By their numbers in this assay, from the lowest: compound 2; then compound 4; then compound 3. At a limit, above all of these: compound 1.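

In this assay the result is a 110-fold lower number from compound 3 to compound 4 (2.05 log units; beyond the scatter), so one chloro on this aromatic carbon, ortho to a large group and meta to the fluoro group, is enough for a large change on its own. The earlier compounds shown here differ from one another in more than one place, so they could not show what this position does alone. Nothing measured here accounts for the size of this step.

Going by these compounds, whether the change is specific to chloro stays open, since a nitrile or an amine on the same carbon could give a different number. On these data alone, whether chloro needs this particular carbon of the ring also stays open.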